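Swapping the tetrazole methyl for phenyl in a thiazole series

This account rests on a few compounds, and the source may have more. Where it says the series, first, only, none or still open, it means among the compounds named here.

Of the compounds shown here, three of one shared core have been tested in a functional assay on C6 cells (Rattus norvegicus) for cytotoxicity, read by MTT assay, with a stated time of 24 h, tested at 25 ug/mL; a lower number here means a stronger effect, a higher number a weaker effect of the compound at the concentration tested. Compound 1 `Cc1ccc(-c2cs/c(=N/NC(=O)CSc3nnnn3-c3ccccc3)n2-c2ccccc2)cc1` gives 38.8%, compound 2 `O=C(CSc1nnnn1-c1ccccc1)N/N=c1/scc(-c2ccc(Cl)cc2)n1-c1ccccc1` gives 62.3%, and compound 3 `Cn1nnnc1SCC(=O)N/N=c1/scc(-c2ccc(C#N)cc2)n1-c1ccccc1` gives 43.9%. Among the compounds with values here, the one single-point step among them, a number 23.5 percentage points higher from compound 1 to compound 2 (beyond the scatter), concerns the group on the aromatic carbon and not the tetrazole. Compound 3 and compound 1 lie within the scatter of each other, while compound 2 sits beyond the scatter above compound 3.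

Compound 4 `N#Cc1ccc(-c2cs/c(=N/NC(=O)CSc3nnnn3-c3ccccc3)n2-c2ccccc2)cc1` differs from compound 3 in a single place: phenyl in place of methyl on an aromatic nitrogen. Within the data shown here, no measured pair isolates this change, since compound 1 and compound 2 already carry the phenyl on the tetrazole nitrogen but differ from compound 3 at the aromatic carbon as well. Among the measured compounds shown here, the only measured step, from compound 1 to compound 2, therefore gives no guide to the size or direction of the new step. For the measured compounds named here, with no direct precedent, the expected step of a number 0.1 percentage points higher from compound 3 to compound 4 (within the scatter) is none beyond the scatter, and the estimate for compound 4 in this assay is 44%, with a range from 25% to 65% that is deliberately wide.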

Compound 4, a percentage reported as activity, at one concentration (the size of the read-out at that concentration, not a potency): 64.2%
For compound 4 the middle estimate is 20.2 percentage points below the measured one; the measured number falls inside the stated range.
By their numbers in this assay, from the lowest: compounds 1 and 3 (each within the scatter of the next); then compounds 2 and 4 (each within the scatter of the next).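

In this assay, within the data shown here, a number 20.3 percentage points higher from compound 3 to compound 4 (beyond the scatter) is the first direct reading of phenyl in place of methyl on the aromatic nitrogen of the tetrazole: the step lies beyond the scatter, so this position does affect the read-out, and the larger group goes with a weaker effect at the concentration tested. With the 1-phenyl-1H-tetrazol-5-yl group held constant, the group on the aromatic carbon can also be compared: cyano in place of chloro gives a number 1.9 percentage points higher from compound 2 to compound 4 (within the scatter), within the scatter, whereas cyano in place of methyl gives a number 25.4 percentage points higher from compound 1 to compound 4 (beyond the scatter), beyond it, so in this small set cyano reads like chloro and apart from methyl. Nothing available explains either the tetrazole step or this difference on the aromatic carbon.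

Among these compounds, only one pair isolates the change on the tetrazole, so it remains open whether methyl to phenyl would give a step of similar size and direction with chloro or methyl in place of the cyano. Also open, as far as these compounds go, is how other groups on that nitrogen, such as ethyl, benzyl or a chain ending in a carboxylic acid, would read.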